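The source may report more compounds than this note shows. Statements on the series, on what has been measured and on what is new or still open speak of the compounds shown alone.

Compound 1 `Cc1c(C(=O)N=C(N)N)ccc(Cl)c1S(C)(=O)=O` gives 1300 nM in a functional assay for inhibition of sodium/hydrogen exchanger (Oryctolagus cuniculus); a higher number here means a weaker inhibitor, a lower number a stronger inhibitor.
Compound 2 `Cc1cc(-c2ccc(Cl)cc2)c(S(C)(=O)=O)cc1C(=O)N=C(N)N` gives 45 nM in this assay.
Compound 3 `CCc1cc(OC)c(S(C)(=O)=O)cc1C(=O)N=C(N)N` gives 30 nM in this assay.

Among these three numbers compound 2 has the second highest. Its nearest neighbour is compound 3, whose number is lower by an amount that stays within the scatter, so the two cannot be told apart. Compound 1 stands far above both, and that gap lies beyond the scatter.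

Compound 4 `CCOc1cc(C)c(C(=O)N=C(N)N)cc1S(C)(=O)=O` has not yet been measured. It differs from compound 2 in one place: ethoxy in place of 4-chlorophenyl on an aromatic carbon. The shared core keeps its acylguanidine and its methylsulfonyl group; only the group on that one aromatic carbon changes.

Among the measured compounds shown here, no pair of measured compounds differs in exactly this way, so there is no measured step to lean on. Compound 3 carries a small oxygen-linked group in place of a ring on its own core and gives 30 nM, close to compound 2, so a step of no size beyond the scatter is expected in this assay from compound 2 to compound 4, that is a 1.1-fold lower number from compound 2 to compound 4 (0.05 log units; within the scatter). Compound 4 is therefore estimated at 40 nM, in a range from 12 nM to 130 nM.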

Compound 4, half-maximal inhibitory concentration: 19 nM
Compound 4: middle estimate off by 2.1-fold (0.32 log units), on the high side; the measured number falls inside the stated range.
By their numbers in this assay, from the lowest: compounds 4, 3 and 2 (each within the scatter of the next, the first and the last beyond it); then compound 1.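

In this assay, ethoxy in place of 4-chlorophenyl gives a 2.4-fold lower number from compound 2 to compound 4 (0.37 log units; beyond the scatter), a modest step but one that lies beyond the scatter. On this aromatic carbon, ortho to a methylsulfonyl group, a ring is therefore not needed for a low number: on the shared core, ethoxy, with no ring and fewer heavy atoms, gives a lower number than 4-chlorophenyl.

From the compounds shown here alone, with only these two groups compared on this core, it remains open whether the step follows the loss of the ring, the smaller size or the linking oxygen, and a butoxy chain or an amine on the same carbon would help to separate these readings. Nothing measured here gives a reason for the step.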